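This account rests on a few compounds, and the source may have more. Where it says the series, first, only, none or still open, it means among the compounds named here.

Measured so far:
compound 1 `O=C1NC(=S)/C(=C/c2ccc(Cl)cc2)S1`: 3.91%
compound 2 `O=C1NC(=S)/C(=C/c2ccccc2Cl)S1`: -11.5%

Compound 1 has the higher of the two numbers in a functional assay on HEp-2 cells (Homo sapiens) for cytotoxicity, read by MTT assay, with a stated time of 72 h, tested at 2.5 ug/mL; a lower number here means less inhibition of growth, a higher number more inhibition of growth at the concentration tested; compound 2 lies lower, beyond the scatter, and both numbers sit close to no inhibition at the concentration tested. Compound 3 `O=C1NC(=S)/C(=C/c2ccc(Cl)c(Cl)c2)S1` differs from compound 1 by chloro in place of hydrogen on an aromatic carbon. Among the measured compounds shown here, no measured pair covers this change. Because compound 1 gives only 3.91% in this assay, the step is expected to be small, a number 4.1 percentage points higher from compound 1 to compound 3 (within the scatter), upward if anything and possibly not beyond the scatter. Compound 3 is thus estimated at 8% in this assay, with a range from -10% to 30%.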

Compound 3, percent growth inhibition at one concentration: 5.03%
The estimate for compound 3 lay 3 percentage points above the measured number, and the stated range covers the measured number.
By their numbers in this assay, from the lowest: compound 2; then compounds 1 and 3 (each within the scatter of the next).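

In this assay, chloro in place of hydrogen on an aromatic carbon, ortho to a chloro group and meta to a group of 8 heavy atoms, gives a number 1.1 percentage points higher from compound 1 to compound 3 (within the scatter) for the added chloro. At this position, then, a second chloro on the ring of compound 1 leaves the read-out within the scatter. No supporting measurement bears on this step. Open, going by these compounds, is whether an amine, a carboxylic acid or a methoxy group at the same position would give a step beyond the scatter, and whether any such group would move the series clearly away from no inhibition.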